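The source may report more compounds than this note shows. Statements on the series, on what has been measured and on what is new or still open speak of the compounds shown alone.

Compounds measured so far:
- compound 1, `N#Cc1c(NCc2ccccc2)c(Cl)c2nc(N)nc(N)c2c1F`, 1.4 ug/mL
- compound 2, `CCN(CC)c1c(C#N)c(F)c2c(N)nc(N)nc2c1Cl`, 2 ug/mL

In a functional assay on HepG2 cells (Homo sapiens) for cytotoxicity, read by MTT assay (a higher number here means a weaker inhibitor, a lower number a stronger inhibitor), compound 1 gives 1.4 ug/mL and compound 2 gives 2 ug/mL, two numbers within the scatter of each other, so compound 1 stands alongside compound 2 rather than apart from it. For the measured compounds named here, the only measured step, a 1.4-fold higher number from compound 1 to compound 2 (0.15 log units; within the scatter), swaps one amine for another and stays within the scatter.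

Compound 3, `N#Cc1c(NCc2ccccc2)c(Cl)c2nc(N)nc(N)c2c1NCc1ccccc1`, differs from compound 1 by benzylamino in place of fluoro on an aromatic carbon. Going by the values given here, no measured step touches this position, and the one known step argues for little movement. Compound 3 is therefore expected to show a 1.4-fold higher number from compound 1 to compound 3 (0.15 log units; within the scatter), nothing beyond the scatter. The estimate for compound 3 is 2 ug/mL, ranging from 0.7 ug/mL to 6 ug/mL.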

Compound 3, half-maximal inhibitory concentration: 19.2 ug/mL
Compound 3: middle estimate off by 9.6-fold (0.98 log units), on the low side; the measured number lies above the stated range.
By their numbers in this assay, from the lowest: compounds 1 and 2 (each within the scatter of the next); then compound 3.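

In this assay, the place ortho to a cyano group responds strongly, unlike the earlier swap of one amine for another: benzylamino in place of fluoro gives a 14-fold higher number from compound 1 to compound 3 (1.14 log units; beyond the scatter) and so a weaker inhibitor. A second benzylamino group is therefore not interchangeable with fluoro at this place on the shared core. No available evidence accounts for this shift.

The compounds shown leave open whether a simple amino group or a methoxy group at this place would stay close to compound 1. They also leave open whether losing fluoro or gaining the benzene ring matters more.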